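Removing a ring chloro from a dichloropurine cytotoxic series

The compounds below may be only part of what the source reports. "The series", "measured", "known", "first", "only" and "open" are said of these compounds alone.

Measured so far:
Compound 1, `ClCc1cccc(Cn2cnc3nc(Cl)nc(Cl)c32)c1`, 30900 nM
Compound 2, `ClCc1ccccc1Cn1cnc2c(Cl)ncnc21`, 4360 nM
Compound 3, `ClCc1ccc(Cn2cnc3ncnc(Cl)c32)cc1`, 30900 nM

All three were tested in a functional assay on NCI-H23 cells (Homo sapiens) for cytotoxicity, read by sulforhodamine B assay, with a stated time of 48 h; a lower number here means a stronger inhibitor of growth, a higher number a weaker inhibitor of growth. Compound 1 gives 30900 nM there, level with compound 3 at the digits shown, and together these two give the highest numbers of the set; the two values lie within the scatter, so no order between them can be claimed. Compound 2, with 4360 nM, stands apart with a clearly lower number, beyond the scatter.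

Compound 4, `ClCc1cccc(Cn2cnc3ncnc(Cl)c32)c1`, has not yet been measured. It differs from compound 1 in one place: hydrogen in place of chloro on an aromatic carbon. The chloro that leaves sits between two ring nitrogen atoms of the shared core, meta to the remaining chloro group.

Going by the values given here, no pair among the measured compounds differs in this single change, so its effect must be guessed. The step of a 1.2-fold lower number from compound 1 to compound 4 (0.09 log units; within the scatter) is expected to be small, within or barely beyond the scatter, leaning if anything toward a lower number. Compound 4 is estimated at 25000 nM, with a range from 8000 nM to 60000 nM.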

Compound 4, concentration for total growth inhibition: 3380 nM
Estimate against measurement, compound 4: 7.4-fold (0.87 log units) above, and the stated range ends above it.
By their numbers in this assay, from the lowest: compounds 4 and 2 (each within the scatter of the next); then compounds 1 and 3 (each within the scatter of the next).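

In this assay, hydrogen in place of chloro on the aromatic carbon between two ring nitrogen atoms of the shared core gives a 9.1-fold lower number from compound 1 to compound 4 (0.96 log units; beyond the scatter) and so shows that this position is not silent in this assay. Going by these compounds alone, the earlier compounds offered no pair that isolated this position, and this is the first single change in the set whose size can be read. Nothing at hand accounts for the step.

Open, from the compounds shown here alone, is whether another group at this position, such as an amine or a methoxy group, would give a number like that of compound 4 or like that of compound 1. Also open, going by these compounds, is whether the same change would give a step of this size in any other pair, since this single pair is all that carries it.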